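The source may report more compounds than this note shows. Statements on the series, on what has been measured and on what is new or still open speak of the compounds shown alone.

Series notes. Compound 1 `Nc1ncnc2c1ncn2[C@@H]1O[C@H](COC(=O)OCc2ccccc2)[C@@H](O)[C@H]1O` carries a carbonyl arm bearing a benzyloxy group. In an assay on COS-7 cells for inhibition of sodium/nucleoside cotransporter 2 (Homo sapiens), read by scintillation counting, in the presence of a further agent that is not named here (a higher number here means a weaker inhibitor, a lower number a stronger inhibitor), compound 1 gives > 100000 nM. That figure is a limit of the assay, not a number; compound 1 sits at the limit of > 100000 nM in this assay, at which 1 of the 3 values shown sits. Two differently built compounds return numbers: compound 2 `Nc1ncnc2c1nc(NCc1ccc(-c3ccccc3)cc1)n2[C@@H]1O[C@H](CO)[C@@H](O)[C@H]1O` gives 640 nM in this assay, and compound 3 `Nc1ncnc2c1nc(NCc1ccc3ccccc3c1)n2[C@@H]1O[C@H](CO)[C@@H](O)[C@H]1O` gives 5300 nM. Compound 1 thus stands apart from both of them, since it alone is reported as a limit. Among the measured compounds shown here, no two of the measured compounds differ in one place, so no measured step is available, and the gap between compound 2 and compound 3 is stated here only as what their two values show.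

Compound 4 `CCNC(=O)OC[C@H]1O[C@@H](n2cnc3c(N)ncnc32)[C@H](O)[C@@H]1O` is the next compound. Relative to compound 1 the change is ethylamino in place of benzyloxy on a carbonyl carbon. The carbonyl arm stays; the benzyloxy leaves and ethylamino enters on the carbonyl carbon whose other neighbour is the oxygen next to the carbonyl group.

For the measured compounds named here, with compound 1 at a limit and no measured step to lean on, the step of a number no higher from compound 1 to compound 4 (the limit leaves the size open) is expected to be none beyond the scatter. Compound 4 is accordingly expected to remain at the limit in this assay. Compound 4 is estimated at 100000 nM, with a range from 30000 nM to 300000 nM.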

Compound 4, half-maximal inhibitory concentration: > 100000 nM
Compound 4: a limit, no number (the forecaster's own chance of this, stated with the estimate: 80%); the middle value lies on the limit itself.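

Compound 1 and compound 4 both stand at a limit in this assay, not at a number, so no step can be read between them: the limit of > 100000 nM in this assay, at which 2 of the 4 values shown sit.

The compounds shown leave open whether any group on the carbonyl carbon of this arm would give a readable value in this assay.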